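Two chain-end variants of compound 1, one still unmeasured

A few compounds are considered here, and "the series" means these few. Any claim that something is new, unique, unknown or untested is made for them only; others in the source may bear on it.

Compound 1 `COCCCCCCCCCCC/C=C1\CC(CO)(COC(=O)C(C)(C)C)OC1=O` gives 0.541 ug/mL in a functional assay on COLO 205 cells (Homo sapiens) for antiproliferative activity; a lower number here means a stronger inhibitor of growth, a higher number a weaker inhibitor of growth.
Compound 2 `COC(=O)CCCCCCCCCCCCCC/C=C1\CC(CO)(COC(=O)C(C)(C)C)OC1=O` gives 3.86 ug/mL in this assay.

For the measured compounds named here, compound 1 stands at the lowest of the two numbers in this assay; its only neighbour is compound 2, reached by a 7.1-fold higher number from compound 1 to compound 2 (0.85 log units; beyond the scatter), a step that lies beyond the scatter. Compound 3 `CC(C)(C)C(=O)OCC1(CO)C/C(=C\CCCCCCCCCCCCCCC=O)C(=O)O1` has not been measured. Its difference from compound 1 is 3-formylpropyl in place of methoxy on a saturated chain carbon, ten or more bonds along the chain from a double-bonded chain carbon.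

Going by the values given here, the change sits at the same place as the one that separates compound 1 from compound 2, and in both cases the methoxy gives way to a longer group carrying one hydrogen-bond acceptor. Among the compounds with values here, the only measured step that bears on compound 3 is therefore a 7.1-fold higher number from compound 1 to compound 2 (0.85 log units; beyond the scatter), a modest rise in the number. Whether a 3-formylpropyl behaves like a 3-(methoxycarbonyl)propyl cannot be checked against any other pair here, so the expectation rests on that single step and carries a wide range. For compound 3 the expected step in this assay is a 3.7-fold higher number from compound 1 to compound 3 (0.57 log units; beyond the scatter), towards a higher number. Compound 3 is estimated at 2 ug/mL, within a range from 0.6 ug/mL to 6 ug/mL.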

Compound 3, concentration for 50% growth inhibition: > 10 ug/mL
Compound 3: only a limit was reported (the forecaster's own chance of this, stated with the estimate: 0%); at least 5.0-fold (0.69 log units) between middle value and limit.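

Compound 3 is reported in this assay only as a limit: the limit of > 10 ug/mL in this assay, at which 1 of the 3 values shown sits.

For the compounds shown here, the step read against that limit is an at least 18-fold higher number from compound 1 to compound 3 (1.26 log units; beyond the scatter), so the chain end is more sensitive to change than the single earlier step showed. The new comparison at the carbonyl carbon is an at least 2.5-fold higher number from compound 2 to compound 3 (0.41 log units; beyond the scatter), and it shows that the chain end's terminal group matters as well as the longer chain: 3-formylpropyl and 3-(methoxycarbonyl)propyl have equal chain length and the same counts of hydrogen-bond donors and acceptors, yet compound 3 lies beyond the scatter from compound 2 in the direction of weaker growth inhibition.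

On these data alone, with only a limit for compound 3, the true size of both steps stays open, and these three compounds cannot separate the effect of chain length from that of the terminal group when moving away from compound 1. Also open, as far as these compounds go, is how a carboxylic acid, a primary alcohol or an amine would read at this chain end, and whether a shorter chain ending in methoxycarbonyl would stay close to compound 1.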